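This account rests on a few compounds, and the source may have more. Where it says the series, first, only, none or still open, it means among the compounds named here.

In an ADME assay on Caco-2 cells (Homo sapiens) for permeability, in the apical to basolateral direction (on this read-out lower numbers stand for lower permeability and higher numbers for higher permeability), compound 1 (`COc1ccc(Nc2ccc3c(C4CCN(C)CC4)c[nH]c3c2)cc1OC`) gives 24 10^-6 cm/s and compound 2 (`Fc1ccc(Nc2ccc3c(C4CCNCC4)c[nH]c3c2)cc1F`) gives 7.1 10^-6 cm/s as the lower of the two numbers, a gap beyond the usual scatter. The two compounds differ in more than one place, so that gap isolates no single change. Compound 3 (`Cn1cc(C2CCNCC2)c2ccc(Nc3ccc(F)c(F)c3)cc21`) has methyl in place of hydrogen on an aromatic nitrogen of compound 2 (methyl in place of hydrogen on an aromatic nitrogen), two ring bonds from the ring atom that bears a piperidin-4-yl group. Among the measured compounds shown here, no measured pair shows this change on its own, so the expectation rests on the structural change alone and remains uncertain. In this assay a small upward step is expected, and the estimated step (a 1.7-fold higher number from compound 2 to compound 3 (0.23 log units; within the scatter)) does not go beyond the scatter. For compound 3 the estimated value is 12 10^-6 cm/s (expected range 5 10^-6 cm/s to 26 10^-6 cm/s).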

Compound 3, apparent permeability: 3 10^-6 cm/s
For compound 3 the middle estimate is 4.0-fold (0.60 log units) above the measured one; measured number below the stated range.
By their numbers in this assay, from the lowest: compound 3; then compound 2; then compound 1.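

In this assay, among the compounds shown here, methyl in place of hydrogen on an aromatic nitrogen gives a 2.4-fold lower number from compound 2 to compound 3 (0.37 log units; beyond the scatter) and is the first single change whose effect can be read on its own. The step lies beyond the usual scatter, so this position, two ring bonds from the ring atom that bears a piperidin-4-yl group, is not silent on this read-out, and a single added carbon is enough to move the number down. Nothing available here explains why the number falls.

The compounds shown leave open whether an ethyl group, a longer chain or a chain ending in an amine on the same nitrogen would move the number in the same direction and by a similar amount. They also leave open whether the same methyl would have a similar effect on compound 1, which differs from compound 2 in more than one place.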